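The compounds below may be only part of what the source reports. "The series", "measured", "known", "first", "only" and "open" are said of these compounds alone.

Compound 2 `COCC(=O)N1CCO[C@@H](c2nc(-c3ccc(C(=O)Nc4cc(C(F)(F)F)ccn4)cc3F)c3c(N)nccn23)C1` carries the shared core with a 4-((methoxymethyl)carbonyl)morpholin-2-yl group. Among the compounds with values here, in an ADME assay on the whole organism for metabolic stability, with Rattus norvegicus as the target, at a dose of 10 mg/kg (a lower number here means that the compound disappears faster, a higher number that the compound lasts longer), compound 2 gives 0.8 h, the lowest of the two numbers so far; compound 1 `C[C@H]1CO[C@@H](c2nc(-c3ccc(C(=O)Nc4cc(C(F)(F)F)ccn4)cc3F)c3c(N)nccn23)CN1C(=O)C1CC1` gives 3.9 h. Within the data shown here, the one step already measured, a 4.9-fold lower number from compound 1 to compound 2 (0.69 log units; beyond the scatter), runs in the opposite direction to the one now considered and changes the same acyl group together with the ring methyl. Compound 3 `CC(C)C(=O)N1CCO[C@@H](c2nc(-c3ccc(C(=O)Nc4cc(C(F)(F)F)ccn4)cc3F)c3c(N)nccn23)C1` differs from compound 2 by isopropyl in place of methoxymethyl on a carbonyl carbon. This partly reverses the earlier step, returning a carbon-only acyl substituent, so a move back up toward compound 1 is plausible, though the loss of the ring methyl is not reversed and nothing isolates the acyl part of that step. For compound 3 in this assay the expected step is a 2.0-fold higher number from compound 2 to compound 3 (0.30 log units; within the scatter), an estimate of 1.6 h with a range of 0.7 h to 3.5 h.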

Compound 3, half-life: 2.3 h
Beside the measured number, compound 3's estimate is 1.4-fold (0.16 log units) below it; the range from low to high includes it.
By their numbers in this assay, from the lowest: compound 2; then compounds 3 and 1 (each within the scatter of the next).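

In this assay, the swap of methoxymethyl for isopropyl on a carbonyl carbon gives a 2.9-fold higher number from compound 2 to compound 3 (0.46 log units; beyond the scatter); the earlier step changed the acyl group and the ring methyl together, whereas this one shows that a change at this position alone can move the half-life beyond the scatter. The remaining gap, a 1.7-fold lower number from compound 1 to compound 3 (0.23 log units; within the scatter), lies within the scatter, so 4-(isopropylcarbonyl)morpholin-2-yl and 4-(cyclopropylcarbonyl)-5-methylmorpholin-2-yl cannot be told apart here. No available evidence bears on this result.

The contribution of the ring methyl taken alone remains unresolved, as no pair of compounds shown separates it from the acyl group. Also open, from the compounds shown here alone, is how the half-life responds on the same carbonyl carbon to a dimethylaminomethyl group, a carboxylic acid-bearing chain or a longer carbon chain such as n-butyl.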